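A Cyclopropyl Swap on a Saturated Chain Carbon

The compounds below may be only part of what the source reports. "The series", "measured", "known", "first", "only" and "open" are said of these compounds alone.

Among the measured compounds shown here, in a functional assay on SW1573 cells (Homo sapiens) for antiproliferative activity, read by sulforhodamine B assay, with a stated time of 48 h (a lower number here means a stronger inhibitor of growth, a higher number a weaker inhibitor of growth), compound 1 (`CCC(C#CC(=O)OC)O/C=C/C(=O)OC`) gives 540 nM and compound 2 (`COC(=O)C#CC(CC(C)C)O/C=C/C(=O)OC`) gives 380 nM as the only other number so far, and the two lie within the scatter of each other. Compound 2 therefore stands with compound 1, and neither can be set apart from the other. Compound 3 (`COC(=O)C#CC(O/C=C/C(=O)OC)C1CC1`) carries cyclopropyl in place of isobutyl on a saturated chain carbon bound to an oxygen on an unsaturated carbon and a triple-bonded carbon. For the measured compounds named here, only one measured step bears on this change. In this assay the swap of isopropyl in place of methyl gives a 1.4-fold lower number from compound 1 to compound 2 (0.15 log units; within the scatter) and so stays small. Going by the values given here, no compound with a ring on that carbon has been measured, which leaves the ring itself untested. The expectation thus rests on compound 2 at 380 nM and on that one small step, and no shift beyond the scatter is expected. The step expected is a 1.2-fold higher number from compound 2 to compound 3 (0.07 log units; within the scatter) and it lies within the scatter. Compound 3 is estimated at 450 nM with a range from 200 nM to 1000 nM as the expected spread of a measurement.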

Compound 3, concentration for 50% growth inhibition: 1800 nM
Estimate against measurement, compound 3: 4.0-fold (0.60 log units) below, and the stated range ends below it.
By their numbers in this assay, from the lowest: compounds 2 and 1 (each within the scatter of the next); then compound 3.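

At this saturated chain carbon, bound to an oxygen on an unsaturated carbon and a triple-bonded carbon, the earlier compounds had shown only that ethyl and isobutyl lie within the scatter of each other, so the position could have seemed indifferent to what it carries. Cyclopropyl shows that it is not: in this assay the swap from isobutyl gives a 4.7-fold higher number from compound 2 to compound 3 (0.68 log units; beyond the scatter) and the swap from ethyl gives a 3.3-fold higher number from compound 1 to compound 3 (0.52 log units; beyond the scatter) and both steps lie beyond the scatter, in the same direction, leaving the compound with the ring a weaker inhibitor of growth than either open-chain compound. Nothing measured here accounts for why the ring reads this way.

As far as these compounds go, whether this loss belongs to rings on this carbon in general or to the three-membered ring alone remains open, and a cyclopentyl or cyclohexyl group on the same carbon would bear on that. From the compounds shown here alone, how far the position tolerates other kinds of group is also open, such as an amine, a phenyl ring or a longer chain like n-hexyl.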